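One Double Bond, Drawn Two Ways

The source may report more compounds than this note shows. Statements on the series, on what has been measured and on what is new or still open speak of the compounds shown alone.

Measured so far in a functional assay on HeLa cells (Homo sapiens) for inhibition; a lower number here means a stronger inhibitor, a higher number a weaker inhibitor
- Compound 1 (`COc1cc(/C=C\c2ccc3ccccc3c2)cc([N+](=O)[O-])c1OC`) gives 110 nM
- Compound 2 (`COc1cc(/C=C/c2ccc3ccccc3c2)cc(N)c1OC`) gives 460 nM

Compound 2 has the higher of these two numbers, which makes it the weaker inhibitor, and its gap to compound 1 lies beyond the usual scatter. The next molecule, compound 3 (`COc1cc(/C=C\c2ccc3ccccc3c2)cc(N)c1OC`), is built from the same atoms and bonds as compound 2. The only difference is its geometry (the two compounds have the same atoms and bonds and differ only in configuration as drawn: 1 of 1 stereo elements differ; a double bond is drawn E in compound 2 and Z in compound 3): a double bond is drawn E in compound 2 and Z in compound 3.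

Among the compounds with values here, no two measured compounds differ in just one place, so the size of this change has not been observed directly. Within the data shown here, the only available clue is compound 1 (110 nM), whose double bond is also drawn Z and whose number is the lower of the two. On that single hint, a clear fall is expected, larger than the scatter (a 6.6-fold lower number from compound 2 to compound 3 (0.82 log units; beyond the scatter)) in this assay as the read-out. The estimate for compound 3 is 70 nM (expected range 20 nM to 250 nM) until the measurement arrives.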

Compound 3, half-maximal inhibitory concentration: 1640 nM
The estimate for compound 3 lay 23-fold (1.37 log units) below the measured number; measured number above the stated range.
By their numbers in this assay, from the lowest: compound 1; then compound 2; then compound 3.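

In this assay, the geometry of the double bond matters on its own, and the Z form is the weaker inhibitor of this pair (a 3.6-fold higher number from compound 2 to compound 3 (0.55 log units; beyond the scatter)). That step can be assigned to the double bond alone, because nothing else separates the two structures: the fact that compounds 2 and 3 differ only in the configuration as drawn. Holding the Z geometry fixed, the group on the aromatic carbon also counts, with amino in place of nitro giving a large loss (a 15-fold higher number from compound 1 to compound 3 (1.17 log units; beyond the scatter)), so the low number of compound 1 cannot be credited to Z geometry alone, as compound 3 shares that geometry and sits far higher.

The compounds shown leave open whether the E form would still be the stronger inhibitor with a nitro group in place of amino, so the effects of the double bond and of the group on the aromatic carbon cannot yet be treated as independent. They also leave open how other groups on that aromatic carbon, such as a hydroxyl, a nitrile or an acetamide, would compare with amino and nitro.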